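The compounds below may be only part of what the source reports. "The series", "measured", "known", "first", "only" and "open" are said of these compounds alone.

Compound 1 `COc1ccc(CSc2nnc(-c3cc(OC)c(OC)c(OC)c3)n2-c2ccc(OC)cc2)cc1`: 40300 nM
Compound 2 `COc1ccc(-n2c(SCC(=O)c3ccc(F)cc3)nnc2-c2cc(OC)c(OC)c(OC)c2)cc1`: 58300 nM

Both numbers come from a functional assay on PC-3 cells (Homo sapiens) for inhibition, read by MTT assay, with a stated time of 48 h; a lower number here means a stronger inhibitor, a higher number a weaker inhibitor. Compound 2 gives 58300 nM, level with compound 1 once the usual scatter is allowed for. Going by the values given here, the only measured step is a 1.4-fold higher number from compound 1 to compound 2 (0.16 log units; within the scatter), with (4-fluorophenyl)carbonyl in place of 4-methoxyphenyl on a saturated chain carbon bound to a sulfur.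

Compound 3 `COc1ccc(-n2c(SCC(=O)c3ccc(OC)c(O)c3)nnc2-c2cc(OC)c(OC)c(OC)c2)cc1` keeps everything else in compound 2 and changes one group: 3-hydroxy-4-methoxyphenyl in place of 4-fluorophenyl on a carbonyl carbon. In words, 3-hydroxy-4-methoxyphenyl stands in place of 4-fluorophenyl on a carbonyl carbon. Among the compounds with values here, no measured step changes this group while keeping the carbonyl, so the evidence is thin. Within the data shown here, the one guide is compound 2, which at 58300 nM stays within the scatter of compound 1 even though a whole group differs. A small step is therefore expected in this assay, with only a slight lean towards a lower number and no firm direction. The expected change is a 1.9-fold lower number from compound 2 to compound 3 (0.29 log units; within the scatter). For compound 3 the estimate is 30000 nM, with an expected range from 8000 nM to 80000 nM.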

Compound 3, half-maximal inhibitory concentration: > 60000 nM
Compound 3 gave a limit, no number; the forecaster's own chance of this, stated with the estimate: 10%; middle value at least 2.0-fold (0.30 log units) from the limit.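

In this assay compound 3 gives a limit of the assay and no number: the limit of > 60000 nM in this assay, at which 1 of the 3 values shown sits.

On these data alone, putting 3-hydroxy-4-methoxyphenyl in place of 4-fluorophenyl on a carbonyl carbon gives an at least 1.0-fold higher number from compound 2 to compound 3 (0.01 log units; that floor lies within the scatter), and the wider change of (3-hydroxy-4-methoxyphenyl)carbonyl in place of 4-methoxyphenyl on a saturated chain carbon bound to a sulfur gives an at least 1.4-fold higher number from compound 1 to compound 3 (0.17 log units; that floor lies within the scatter); both are only floors, within the scatter, so the true size of each step stays unknown. This is the first change shown on this carbonyl carbon, and it shows that an aromatic ring carrying a hydrogen-bond donor and two hydrogen-bond acceptors, where 4-fluorophenyl carried none, brought no sign of a lower number in this assay.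

The compounds shown leave open whether any other group on this carbonyl carbon, such as an unsubstituted phenyl or a phenyl bearing an amine or a carboxylic acid, would give a lower number. They also cannot separate the hydroxy from the methoxy, since the two enter together in compound 3.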